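This account rests on a few compounds, and the source may have more. Where it says the series, first, only, none or still open, it means among the compounds named here.

Of the compounds shown here, two from a shared series have been tested in a functional assay on SK-BR-3 cells (Homo sapiens) for antiproliferative activity, read by MTT assay, with a stated time of 72 h; a higher number here means a weaker inhibitor, a lower number a stronger inhibitor. Compound 1, `CCN1CCN(c2cc(C)c3cc(NC(=O)c4cccc(Cl)c4)ccc3n2)CC1`, gives 17800 nM in this assay. Compound 2, `Cc1cc(N2CCCCC2)nc2ccc(NC(=O)c3ccc(Cl)c(Cl)c3)cc12`, gives 42500 nM in this assay. Of these two numbers compound 1 holds the lowest, and its nearest neighbour, compound 2, sits a gap away that goes beyond the usual scatter of repeated measurements, so compound 1 is the stronger inhibitor of the pair.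

Compound 3, `CCN1CCN(c2cc(C)c3cc(NC(=O)c4ccco4)ccc3n2)CC1`, has not yet been measured. It differs from compound 1 in one place only: furan-2-yl in place of 3-chlorophenyl on a carbonyl carbon. Within the data shown here, compound 2 differs from compound 1 in more than one place, so no single-change step between measured compounds is available to guide an expectation. The step is therefore expected to be modest and is estimated as a 1.7-fold higher number from compound 1 to compound 3 (0.23 log units; within the scatter), pointing towards a somewhat higher number, that is, slightly weaker inhibition, though a result within the scatter would not surprise. Compound 3 is accordingly expected to give about 30000 nM in this assay, within an estimated range from 8000 nM to 120000 nM.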

Compound 3, half-maximal inhibitory concentration: 37500 nM
Estimate against measurement, compound 3: 1.3-fold (0.10 log units) below, and the stated range covers the measured number.
By their numbers in this assay, from the lowest: compound 1; then compounds 3 and 2 (each within the scatter of the next).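

Among these compounds, this is the first step in this assay where only one place changes, so the group on the carbonyl carbon can be judged with the rest of compound 1 held fixed. Putting furan-2-yl in place of 3-chlorophenyl gives a 2.1-fold higher number from compound 1 to compound 3 (0.32 log units; beyond the scatter), a modest step but one beyond the usual scatter, which shows that the number responds to the group at this position and that, in this pair, the six-membered carbon ring bearing chlorine gives the lower number. Nothing available explains why the furan-2-yl compound gives the higher number.

This single step changes the ring and removes the chlorine together, so a plain phenyl group on the same carbonyl carbon would be needed to tell the two changes apart, while thiophen-2-yl would test a different five-membered ring. On these data alone, it also remains open whether furan-2-yl would give a step of similar size on the other side of the molecule's pattern of groups, as in compound 2, where the group on the shared core differs as well.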